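The source may report more compounds than this note shows. Statements on the series, on what has been measured and on what is new or still open speak of the compounds shown alone.

Measured in an ADME assay on HaCaT cells (Homo sapiens) for antiproliferative activity; a higher number here means a weaker inhibitor of growth, a lower number a stronger inhibitor of growth:

- Compound 1, `NS(=O)(=O)NCC1CCN(c2cc(-c3ccccc3)ncn2)CC1`, gives a limit of the assay rather than a number: > 100000 nM.
- Compound 2, `COc1ccc(-c2cc(N3CCC(CNS(N)(=O)=O)CC3)ncn2)cc1`, likewise gives only a limit: > 100000 nM.
- Compound 3, `COc1ccccc1-c1cc(N2CCC(CNS(N)(=O)=O)CC2)ncn1`, also gives only a limit: > 100000 nM.

Going by the values given here, compound 3 therefore stands nowhere in particular on a scale of numbers; it sits at the limit of > 100000 nM in this assay, at which 3 of the 3 values shown sit, together with every other measured compound, so no compound can be ranked against another.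

Compound 4, `NS(=O)(=O)NCC1CCN(c2cc(-c3ccccc3Cl)ncn2)CC1`, is the next compound to be measured. It differs from compound 3 in one place: chloro in place of methoxy on an aromatic carbon.

Among the compounds with values here, three measured steps bear on this kind of change at the same part of the molecule. The step that the two limits leave unreadable from compound 1 to compound 3, the step that the two limits leave unreadable from compound 1 to compound 2 and the step that the two limits leave unreadable from compound 2 to compound 3 all run between two limits, so none of them shows a size or a direction. Within the data shown here, nothing measured so far reveals whether a small group on that phenyl ring moves growth inhibition at all. What the data do show is that three closely related compounds all failed to reach a measurable number in this assay.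

On that basis compound 4 is expected to behave like its neighbours, most likely returning a limit again rather than a number, with an estimated value of 150000 nM in a range from 40000 nM to 600000 nM. The expected step is a step that the limit leaves unreadable from compound 3 to compound 4.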

Compound 4, concentration for 50% growth inhibition: > 100000 nM
Compound 4 was reported as a limit; the forecaster's own chance of this, stated with the estimate: 85%; the middle value is on the limit's open side.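

Compound 4 also gives only a limit in this assay, so none of its steps from compound 1, compound 2 or compound 3 can be read, and all four compounds share one result: the limit of > 100000 nM in this assay, at which 4 of the 4 values shown sit.

The compounds shown leave open whether hydrogen, methoxy or chloro on the phenyl ring changes growth inhibition at all.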